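From phenoxy to cyclopropyloxy: a solubility question

This account rests on a few compounds, and the source may have more. Where it says the series, first, only, none or still open, it means among the compounds named here.

Measured in a physicochemical assay for solubility, at pH 6.8 (on this read-out lower numbers stand for lower solubility and higher numbers for higher solubility), so far:
Compound 1 `O=[N+]([O-])c1cn2c(n1)OC[C@@H](NCc1ccc(OC(F)(F)F)cc1Oc1ccccc1)C2` gives 3 ug/mL
Compound 2 `CC(C)N(Cc1ccc(OC(F)(F)F)cc1)[C@@H]1COc2nc([N+](=O)[O-])cn2C1` gives < 2 ug/mL as a limit of the assay

Going by the values given here, compound 1 at 3 ug/mL holds the only actual number in this assay so far. Compound 2 shows only a limit at < 2 ug/mL and no number. Compound 3 `O=[N+]([O-])c1cn2c(n1)OC[C@@H](NCc1ccc(OC(F)(F)F)cc1OC1CC1)C2` has not yet been measured. It keeps the rest of compound 1 and carries cyclopropyl in place of phenyl on an oxygen on an aromatic ring. Among the compounds with values here, no measured pair of compounds covers this change, so the expectation rests on compound 1 alone and remains uncertain. A modest upward step in this assay is expected, estimated as a 2.7-fold higher number from compound 1 to compound 3 (0.43 log units; beyond the scatter) and possibly no larger than the usual scatter. Compound 3 is estimated at 8 ug/mL with an expected range from 3 ug/mL to 25 ug/mL in this read-out.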

Compound 3, solubility: 11 ug/mL
The estimate for compound 3 lay 1.4-fold (0.14 log units) below the measured number; measured number inside the range.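

In this assay, going by these compounds alone, cyclopropyl in place of phenyl on an oxygen on an aromatic ring gives a 3.7-fold higher number from compound 1 to compound 3 (0.56 log units; beyond the scatter), the first change at this position whose size can be read. The step shows that the phenyl on this oxygen can be exchanged for a smaller ring, 3 heavy atoms against 6 and no longer aromatic, with the number in this read-out rising beyond the scatter. Compound 2 offers no such comparison, as it shows only a limit of the assay and not a number: the limit of < 2 ug/mL in this assay, at which 1 of the 3 values shown sits.

A single step cannot separate ring size from the loss of the aromatic ring. On these data alone, whether a longer chain such as butyl, or a chain ending in an amine or a carboxylic acid, would move the number further on this oxygen stays open.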